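The source may report more compounds than this note shows. Statements on the series, on what has been measured and on what is new or still open speak of the compounds shown alone.

Measured so far:
compound 1 `CC(C)(C)c1ccc(C(=O)N2CCC3(CC2)C(=O)N(CC(=O)NCCC(=O)O)CN3c2ccccc2)cc1` — 11400 nM
compound 2 `CC1(C)CC(OC(=O)CN2CN(c3ccccc3)C3(CCN(C(=O)c4ccc(C(C)(C)C)cc4)CC3)C2=O)CC(C)(C)N1` — 1300 nM
compound 3 `CC(C)(C)c1ccc(C(=O)N2CCC3(CC2)C(=O)N(CC(=O)N2CCN(S(C)(=O)=O)CC2)CN3c2ccccc2)cc1` — 19000 nM

In an assay on HEK293 cells for displacement of a labelled ligand from NPC1-like intracellular cholesterol transporter 1 (Homo sapiens) (a higher number here means a weaker inhibitor, a lower number a stronger inhibitor), compound 3 gives the highest number of the three, though one of its two steps is small, a 1.7-fold higher number from compound 1 to compound 3 (0.22 log units; within the scatter), whereas a 15-fold higher number from compound 2 to compound 3 (1.16 log units; beyond the scatter) is large. Compound 4 `CC(C)(C)c1ccc(C(=O)N2CCC3(CC2)C(=O)N(CC(=O)NCN)CN3c2ccccc2)cc1` differs from compound 3 by (aminomethyl)amino in place of 4-(methylsulfonyl)piperazin-1-yl on a carbonyl carbon. Among the measured compounds shown here, no measured step swaps these two groups; the nearest comparisons are a 1.7-fold higher number from compound 1 to compound 3 (0.22 log units; within the scatter), a small move between two amide variants, and an 8.8-fold lower number from compound 1 to compound 2 (0.94 log units; beyond the scatter), in which the one compound carrying an amine gave the lower number. Compound 4 also carries an amine, so a modest drop is expected, a 3.8-fold lower number from compound 3 to compound 4 (0.58 log units; beyond the scatter), with compound 4 estimated at 5000 nM (range 1500 nM to 16000 nM) in this assay.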

Compound 4, half-maximal inhibitory concentration: 26500 nM
Beside the measured number, compound 4's estimate is 5.3-fold (0.72 log units) below it; measured number above the stated range.
By their numbers in this assay, from the lowest: compound 2; then compounds 1, 3 and 4 (each within the scatter of the next, the first and the last beyond it).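

In this assay the small (aminomethyl)amino group gives no separation from the much larger 4-(methylsulfonyl)piperazin-1-yl (a 1.4-fold higher number from compound 3 to compound 4 (0.14 log units; within the scatter)), so an amine on this carbonyl carbon does not by itself lower the number. The gap to the (2,2,6,6-tetramethylpiperidin-4-yl)oxy compound stays large (a 20-fold higher number from compound 2 to compound 4 (1.31 log units; beyond the scatter)), and the amine also sits modestly off the carboxylic acid (a 2.3-fold higher number from compound 1 to compound 4 (0.37 log units; beyond the scatter)). Nothing measured here explains these differences. From the compounds shown here alone, whether compound 2 owes its lower number to its ring amine or to its oxygen link stays open, and a (2,2,6,6-tetramethylpiperidin-4-yl)amino group would separate the two.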